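Swapping the Sulfonyl Aryl Group in a Hydrazide Series

The compounds below may be only part of what the source reports. "The series", "measured", "known", "first", "only" and "open" are said of these compounds alone.

Measured compounds:
compound 1, `CC(=O)Nc1ccc(S(=O)(=O)NNC(=O)c2cccnc2Nc2ccc(Cl)cc2)cc1`: > 100000 nM
compound 2, `O=C(NNS(=O)(=O)c1ccc(F)cc1)c1cccnc1Nc1ccc(Cl)cc1Cl`: 31600 nM

Both were tested in a functional assay on SN12C cells (Homo sapiens) for antiproliferative activity; a higher number here means a weaker inhibitor of growth, a lower number a stronger inhibitor of growth. For compound 1 the result is only a limit, > 100000 nM; it marks the edge of what the assay reports, not a measured number (the limit of > 100000 nM in this assay, at which 1 of the 2 values shown sits). Compound 2 gives 31600 nM in this assay, a weak but real inhibition of growth.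

Compound 3, `O=C(NNS(=O)(=O)c1ccc(Cl)cc1Cl)c1cccnc1Nc1ccc(Cl)cc1`, has not been measured. It differs from compound 1 in one place: 2,4-dichlorophenyl in place of 4-acetamidophenyl on a sulfonyl sulfur. Among the measured compounds shown here, no measured pair shares exactly this change, so the expectation rests on compound 2, which also carries a 2,4-dichlorophenyl group and gives 31600 nM. A modest step toward stronger growth inhibition is expected, an at least 2.5-fold lower number from compound 1 to compound 3 (0.39 log units; beyond the scatter), though it may not exceed the usual scatter. Compound 3 is therefore estimated at 40000 nM, with a range from 10000 nM to 150000 nM, and a fair chance that the assay again reports only a limit.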

Compound 3, concentration for total growth inhibition: > 100000 nM
Compound 3: only a limit was reported; the forecaster's own chance of this, stated with the estimate: 35%; middle value at least 2.5-fold (0.39 log units) from the limit.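

The result for compound 3 is again only a limit, as it is for compound 1, so no step between compound 1 and compound 3 can be read: the limit of > 100000 nM in this assay, at which 2 of the 3 values shown sit.

The compounds shown leave open whether 2,4-dichlorophenyl in place of 4-acetamidophenyl on a sulfonyl sulfur changes growth inhibition at all.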